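Anilino in Place of a Ring Amine: Expected Outcome

The compounds below may be only part of what the source reports. "The series", "measured", "known", "first", "only" and "open" are said of these compounds alone.

Measured compounds:
compound 1, `CC1CCN(c2nc(Cl)nc3c2ncn3Cc2ccc(/C=C/C(=O)Nc3ccccc3N)cc2)CC1`, 4.24%
compound 2, `CCCCn1cnc2c(NCc3ccc(C(=O)Nc4ccccc4N)cc3)nc(Cl)nc21`, 4.89%

Of the compounds shown here, two have been measured in a functional assay on HCT-116 cells (Homo sapiens) for antiproliferative activity, read by CCK-8 assay, with a stated time of 72 h, tested at 2 uM (a lower number here means a weaker effect, a higher number a stronger effect of the compound at the concentration tested), and both give small numbers. Compound 1 holds the lowest of the two values, yet compound 2 lies within the usual scatter of it, so the two numbers show no order between them; each points to a weak effect at the concentration tested.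

Compound 3 `Nc1ccccc1NC(=O)/C=C/c1ccc(Cn2cnc3c(Nc4ccccc4)nc(Cl)nc32)cc1` has not been measured yet. It differs from compound 1 in one place:

anilino in place of 4-methylpiperidin-1-yl on an aromatic carbon

Among the measured compounds shown here, no step between measured compounds is available to guide the size of this change. With compound 1 at 4.24%, close to the bottom of the read-out, the step is expected to stay within the scatter: a number 2.8 percentage points higher from compound 1 to compound 3 (within the scatter). Compound 3 is therefore estimated to give about 7%, with a range from 0% to 25%.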

Compound 3, a percentage reported as inhibition, at one concentration (the size of the read-out at that concentration, not a potency): 7.75%
Compound 3: middle estimate off by 0.8 percentage points, on the low side, within the range that was stated.
By their numbers in this assay, from the lowest: compounds 1, 2 and 3 (each within the scatter of the next).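

In this assay, putting anilino in place of 4-methylpiperidin-1-yl on this aromatic carbon gives a number 3.5 percentage points higher from compound 1 to compound 3 (within the scatter). So a non-aromatic ring can give way to an aromatic ring of carbon only, with the same count of heavy atoms and an added hydrogen-bond donor, without a change in the read-out that stands clear of the scatter, although both compounds show only a weak effect at the concentration tested. Nothing measured here bears on the reason for this result.

Going by these compounds, whether any group at this carbon can lift the read-out clearly remains open, for example morpholin-4-yl, a small primary amine or 4-fluoroanilino. Also open, on these data alone, is whether the same exchange would give a similar step on a compound with a stronger starting value.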